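Lengthening the Acyl Chain on a Weakly Cytotoxic Amide

The source may report more compounds than this note shows. Statements on the series, on what has been measured and on what is new or still open speak of the compounds shown alone.

Compound 1 `CC(=O)N1c2ccccc2CCC1C(=O)Nc1ccccc1O` and compound 2 `CCCC(=O)N1c2ccccc2CCC1C(=O)Nc1ccccc1C(F)(F)F` share the same core, carrying an acyl group on the ring nitrogen and an amide to a substituted phenyl ring. In a functional assay on HCT-15 cells (Homo sapiens) for cytotoxicity, read by sulforhodamine B assay, with a stated time of 72 h (a higher number here means a weaker inhibitor of growth, a lower number a stronger inhibitor of growth), compound 1 gives 54500 nM. For compound 2 the assay reports only its limit, > 70000 nM, so no number is known for it. That limit is the one described by the limit of > 70000 nM in this assay, at which 1 of the 2 values shown sits, and compound 2 sits at it. Compound 3 `CCCCCCCCC(=O)N1c2ccccc2CCC1C(=O)Nc1ccccc1C(F)(F)F` is the next member: it differs from compound 2 by pentyl in place of hydrogen on a saturated chain carbon, three bonds along the chain from a carbonyl carbon, so the short acyl chain becomes a long one while everything else stays unchanged. Among the measured compounds shown here, no pair of measured compounds differs only in this chain length, so nothing measured shows how far such a step moves this assay. The step of an at least 1.1-fold lower number from compound 2 to compound 3 (0.06 log units; that floor lies within the scatter) is therefore expected to be small, in no firm direction, and may not exceed the usual scatter. Compound 3 is thus estimated at about 60000 nM, within a range from 20000 nM to 150000 nM, with a real chance that only a limit is reported again.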

Compound 3, concentration for 50% growth inhibition: 7700 nM
Estimate against measurement, compound 3: 7.8-fold (0.89 log units) above, outside the stated range (below it).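

In this assay, the saturated chain carbon three bonds along the chain from a carbonyl carbon proves to be a place where a change can be read: pentyl in place of hydrogen there gives an at least 9.0-fold lower number from compound 2 to compound 3 (0.95 log units; beyond the scatter). Among the compounds shown here, until this pair, no two measured compounds differed in only one place, so this is the first direct sign that the length of the acyl chain matters for growth inhibition, with the rest of the molecule held constant. The true size of the step could be greater than the printed floor, because compound 2 has only a limit and not a number: the limit of > 70000 nM in this assay, at which 1 of the 3 values shown sits.

For the compounds shown here, with only one such pair, nothing shows whether the number falls steadily as the chain grows, or whether a single chain length in between, such as propyl, would already give most of the change, or whether a longer chain would go further. On these data alone, it also remains open whether a chain ending in an amine or a carboxylic acid would keep the gain, and whether the same lengthening would work with a hydroxyl group in place of the trifluoromethyl group.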